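The source may hold more compounds than are shown below. What is called first, only, known or untested is meant among the compounds shown, and "the series" means these compounds.

Compound 1 `O=C(CCCCC[C@H](NC(=O)[C@@H]1CCCC(=O)N1)C(=O)Nc1ccccc1)NO`: in an assay on isolated protein for inhibition of polyamine deacetylase HDAC10 (Homo sapiens), read by fluorescence (a higher number here means a weaker inhibitor, a lower number a stronger inhibitor), compound 1 gives 51 nM. Compound 2 `O=C(CCCCC[C@H](NC(=O)C1CCCNC1=O)C(=O)Nc1ccccc1)NO`: compound 2 gives 244 nM.

Compound 1 holds the lower of the two numbers; the nearest is compound 2, reached by a 4.8-fold higher number from compound 1 to compound 2 (0.68 log units; beyond the scatter). Compound 3 `O=C(CCCCC[C@H](NC(=O)[C@@H]1CCCC(=O)N1)C(=O)NC1CCCC1)NO` carries cyclopentyl in place of phenyl on an amide-type nitrogen. Among the measured compounds shown here, the only measured step, a 4.8-fold higher number from compound 1 to compound 2 (0.68 log units; beyond the scatter), alters the ring on the carbonyl carbon, not the amide nitrogen, so nothing measured bears directly on this change; it shows only that the series can move beyond the scatter. With no guide, a step of uncertain direction and modest size at most is expected, a 1.6-fold higher number from compound 1 to compound 3 (0.20 log units; within the scatter). Compound 3 is therefore estimated at 80 nM, range 25 nM to 250 nM.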

Compound 3, half-maximal inhibitory concentration: 6830 nM
Beside the measured number, compound 3's estimate is 85-fold (1.93 log units) below it; measured number outside the range, above it.
By their numbers in this assay, from the lowest: compound 1; then compound 2; then compound 3.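

On the amide-type nitrogen, replacing phenyl with cyclopentyl costs far more in this assay (a 130-fold higher number from compound 1 to compound 3 (2.13 log units; beyond the scatter)) than the ring change on the carbonyl carbon (a 4.8-fold higher number from compound 1 to compound 2 (0.68 log units; beyond the scatter)). This position is therefore highly sensitive to the group it carries, and in this series a five-membered non-aromatic carbon ring does not stand in for phenyl. No measurement at hand gives a reason for this loss. Open, from the compounds shown here alone, is whether aromaticity or ring size matters more: cyclohexyl and pyridyl on the same nitrogen would separate the two. Going by these compounds, whether benzyl, with its longer link to the ring, is tolerated also remains open.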